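Amine substituents on the shared core: benzyl in place of ethyl

The compounds below may be only part of what the source reports. "The series", "measured", "known", "first", "only" and "open" are said of these compounds alone.

Measured so far:
compound 1 `CCCCN(CC)Cc1c(C(F)(F)F)nc2n(-c3c(C)cc(C)cc3C)c(Cl)cn12` – 78 nM
compound 2 `CCN(CCC1CC1)Cc1c(C(F)(F)F)nc2n(-c3c(C)cc(C)cc3C)c(Cl)cn12` – 13 nM

Within the data shown here, in an assay on cells for displacement of a labelled ligand from corticotropin-releasing factor receptor 1 (Homo sapiens), with a stated time of 100 min (on this read-out higher numbers stand for weaker inhibition and lower numbers for stronger inhibition), compound 1 stands with the higher of the two numbers; the one measured step, a 6.0-fold lower number from compound 1 to compound 2 (0.78 log units; beyond the scatter), lowers it beyond the scatter. Compound 3 `CCCCN(Cc1ccccc1)Cc1c(C(F)(F)F)nc2n(-c3c(C)cc(C)cc3C)c(Cl)cn12` differs from compound 1 by phenyl in place of methyl on a saturated chain carbon bound to an amine nitrogen. Among the measured compounds shown here, no measured step touches this same place; the step from compound 1 to compound 2 sits on the other amine substituent, one carbon further out, and shows that enlarging an amine substituent with a ring lowered the number there. Taken as a loose guide, the expected step for compound 3 is a 2.0-fold lower number from compound 1 to compound 3 (0.29 log units; within the scatter), towards stronger inhibition but with wide uncertainty. Compound 3 is estimated at 40 nM, range 10 nM to 160 nM.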

Compound 3, inhibition constant: 130 nM
Estimate against measurement, compound 3: 3.3-fold (0.51 log units) below; low and high end bracket the measured number.
By their numbers in this assay, from the lowest: compound 2; then compounds 1 and 3 (each within the scatter of the next).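

In this assay, phenyl in place of methyl on a saturated chain carbon bound to an amine nitrogen gives a 1.7-fold higher number from compound 1 to compound 3 (0.22 log units; within the scatter) and so does not separate the two compounds. This place therefore accepts an added aromatic ring with no change beyond the scatter. Unlike this step, a 6.0-fold lower number from compound 1 to compound 2 (0.78 log units; beyond the scatter) at the other amine substituent lies beyond the scatter, so a ring-bearing enlargement does not lower the number at both places. On these data alone, whether a longer chain carrying the phenyl, or a carboxylic acid on it, would shift the number stays open. No measurement shown bears on this result.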